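Chloro for Methyl on the Acyl Hydrazide Arm

The compounds below may be only part of what the source reports. "The series", "measured", "known", "first", "only" and "open" are said of these compounds alone.

Compound 1 `Cc1ccc(C(=O)NNC(=O)c2cccc(NS(=O)(=O)c3cnc(O)nc3O)c2)cc1`: > 20000 nM
Compound 2 `O=C(NNC(=O)c1ccccc1Cl)c1cccc(NS(=O)(=O)c2cnc(O)nc2O)c1`: 2360 nM
Compound 3 `Cc1ccc(C(=O)NNC(=O)c2ccccc2NS(=O)(=O)c2cnc(O)nc2O)cc1`: > 20000 nM

Of the compounds shown here, three have been measured in a functional assay on MDA-MB-231 cells (Homo sapiens) for antiproliferative activity, read by MTT assay, with a stated time of 24 h; a higher number here means a weaker inhibitor, a lower number a stronger inhibitor. For compound 1 the value in this assay is a limit of the assay, > 20000 nM. Compound 2, in contrast, gives a number in this assay, namely 2360 nM. The change between them, (2-chlorophenyl in place of 4-methylphenyl on a carbonyl carbon), gives a step of an at least 8.4-fold lower number from compound 1 to compound 2 (0.92 log units; beyond the scatter); its size rests on (the limit of > 20000 nM in this assay, at which 2 of the 3 values shown sit), so only a lower bound on the step is known. For compound 3 the value in this assay is again a limit of the assay, > 20000 nM. Compound 3 has the same atoms as compound 1, joined differently; the difference between the two cores is not broken down here.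

Compound 4 `O=C(NNC(=O)c1ccccc1NS(=O)(=O)c1cnc(O)nc1O)c1ccccc1Cl` has not yet been measured. It differs from compound 3 by 2-chlorophenyl in place of 4-methylphenyl on a carbonyl carbon, which is the same change as that from compound 1 to compound 2, made on the core of compound 3 rather than on that of compound 1. Because the step of an at least 8.4-fold lower number from compound 1 to compound 2 (0.92 log units; beyond the scatter) was at least modest, a step of similar size is expected for compound 4 in this assay, estimated as an at least 4.4-fold lower number from compound 3 to compound 4 (0.64 log units; beyond the scatter). Since compound 3 sits at a limit, the starting point is uncertain, and compound 4 could itself remain at the limit. On this basis compound 4 is expected to give about 4500 nM in this assay, most likely between 1500 nM and 20000 nM.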

Compound 4, half-maximal inhibitory concentration: 8310 nM
The estimate for compound 4 lay 1.8-fold (0.27 log units) below the measured number; the range from low to high includes it.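

On the core of compound 3, putting 2-chlorophenyl in place of 4-methylphenyl on a carbonyl carbon again lowers the number in this assay, giving an at least 2.4-fold lower number from compound 3 to compound 4 (0.38 log units; beyond the scatter). The direction of the change therefore holds on both cores shown, and in each pair the compound bearing 2-chlorophenyl gives a number where its 4-methylphenyl partner gives only a limit, which leaves the comparison of the two steps as follows: the same change on two cores in this assay, an at least 8.4-fold lower number (0.92 log units; beyond the scatter) from compound 1 to compound 2 and an at least 2.4-fold lower number (0.38 log units; beyond the scatter) from compound 3 to compound 4; the limit leaves it open whether they differ. This does not establish a fixed size for the change on moving between cores, nor does it show that the change would act in the same direction on any further core, and each step is only a lower bound because its starting point is not a number: the limit of > 20000 nM in this assay, at which 2 of the 4 values shown sit.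

The compounds shown leave open how much of the change comes from losing the 4-methyl group and how much from gaining the 2-chloro group, since neither an unsubstituted phenyl nor a 4-chlorophenyl stands in this place on either core. They also leave open whether a pyridine ring or a longer alkyl chain on the same carbonyl carbon would bring the number down further.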